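Amide variation on the shared core: piperidine analogue

The source may report more compounds than this note shows. Statements on the series, on what has been measured and on what is new or still open speak of the compounds shown alone.

The series keeps the core of compound 1 `CCCCc1oc2ccccc2c1C(=O)c1ccc(OCC(=O)NC(C)C)cc1` and varies the amide on the carbonyl carbon. In a functional assay on MDA-MB-231 cells (Homo sapiens) for antiproliferative activity, read by MTT assay, with a stated time of 24 h (on this read-out lower numbers stand for stronger inhibition and higher numbers for weaker inhibition), compound 1 gives only a limit, > 50000 nM. Compound 2 `CCCCNC(=O)COc1ccc(C(=O)c2c(CCCC)oc3ccccc23)cc1` in this assay gives 34500 nM. Compound 3 `CCCCc1oc2ccccc2c1C(=O)c1ccc(OCC(=O)N2CCCC2)cc1` in this assay returns a limit as well, > 50000 nM. Two of the three values thus sit at the limit of > 50000 nM in this assay, at which 2 of the 3 values shown sit, so compound 1 stands at the limit rather than at a number. The step of an at least 1.4-fold lower number from compound 1 to compound 2 (0.16 log units; that floor lies within the scatter) stays within the scatter, as does an at least 1.4-fold higher number from compound 2 to compound 3 (0.16 log units; that floor lies within the scatter); the step that the two limits leave unreadable from compound 1 to compound 3 cannot be read from two limits. Compound 4 `CCCCc1oc2ccccc2c1C(=O)c1ccc(OCC(=O)N2CCCCC2)cc1` is not yet measured. It differs from compound 1 by piperidin-1-yl in place of isopropylamino on a carbonyl carbon. The nearest measured change is the ring amide of compound 3, which remains at the limit > 50000 nM. Compound 4 is therefore expected to remain at the limit as well, with an estimated 50000 nM spanning 30000 nM to 100000 nM. The expected step of a number no higher from compound 1 to compound 4 (the limit leaves the size open) amounts to no change beyond the scatter.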

Compound 4, half-maximal inhibitory concentration: > 50000 nM
Compound 4 gave a limit, no number; the forecaster's own chance of this, stated with the estimate: 70%; the middle value lies on the limit itself.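

Widening the ring on the carbonyl carbon from pyrrolidin-1-yl to piperidin-1-yl gives no number in this assay, so both ring amides shown, compound 3 and compound 4, stay at the limit, as does compound 1 with its isopropylamino group and amide hydrogen: the limit of > 50000 nM in this assay, at which 3 of the 4 values shown sit.
Among these compounds, the one readable new step is an at least 1.4-fold higher number from compound 2 to compound 4 (0.16 log units; that floor lies within the scatter), which leaves the butylamino and piperidin-1-yl amides not separated in this read-out. The steps to compound 4 from compound 1 and from compound 3 cannot be read, as each joins two limits.

On these data alone, it remains open whether any amide at this position gives a clearly stronger number than the butylamino amide. A morpholin-4-yl or piperazin-1-yl ring, a chain longer than butyl on the amide nitrogen, or a carboxylic acid in place of the amide would bear on this.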